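Phenoxy swap on the shared diamine core

The source may report more compounds than this note shows. Statements on the series, on what has been measured and on what is new or still open speak of the compounds shown alone.

Measured so far in a functional assay on MCF7 cells (Homo sapiens) for inhibition, read by sulforhodamine B assay, with a stated time of 48 h; a higher number here means a weaker inhibitor of growth, a lower number a stronger inhibitor of growth:
compound 1 `Nc1cc(N)c2nc(-c3ccccc3)c(Oc3ccc(Cl)c(Cl)c3)nc2c1`, 70800 nM
compound 2 `COc1ccc(CNc2nc3cc(N)cc(N)c3nc2-c2ccccc2)cc1OC`, < 100000 nM
compound 3 `COc1cc(CNc2nc3cc(N)cc(N)c3nc2-c2ccccc2)cc(OC)c1OC`, < 50200 nM

Among the measured compounds shown here, compound 1 supplies the only true number in this assay; the other two values are limits. For compound 2 the value is a limit, (the limit of < 100000 nM in this assay, at which 1 of the 3 values shown sits). For compound 3 the value is also a limit, (the limit of < 50200 nM in this assay, at which 1 of the 3 values shown sits). The step between them, a step that the two limits leave unreadable from compound 2 to compound 3, therefore tells nothing about size.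

Compound 4 `Nc1cc(N)c2nc(-c3ccccc3)c(Oc3ccc(F)cc3)nc2c1` differs from compound 1 by 4-fluorophenyl in place of 3,4-dichlorophenyl on an oxygen on an aromatic ring. For the measured compounds named here, no measured step touches this change: the single measured pair, compound 2 to compound 3, concerns a methoxy in place of hydrogen on an aromatic carbon and is unreadable anyway. With nothing to anchor the direction, the working expectation is that compound 4 stays near compound 1, with any shift likely within the scatter, so the step of a 1.2-fold higher number from compound 1 to compound 4 (0.08 log units; within the scatter) is expected to be small. Compound 4 is estimated at 85000 nM, between 35000 nM and 200000 nM, with a real chance that only a limit is reported.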

Compound 4, concentration for total growth inhibition: < 100000 nM
Compound 4 ended at the assay's limit; the forecaster's own chance of this, stated with the estimate: 40%; the middle value lies beyond the limit too.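

In this assay, among the compounds shown here, compound 4 gives only a limit, so no step from compound 1 to compound 4 can be read: the limit of < 100000 nM in this assay, at which 2 of the 4 values shown sit.

The compounds shown leave open whether 4-fluorophenyl in place of 3,4-dichlorophenyl on an oxygen on an aromatic ring changes growth inhibition at all, and in which direction.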